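Replacing 3-methylphenyl with 2-methoxyphenyl on the shared core

The source may report more compounds than this note shows. Statements on the series, on what has been measured and on what is new or still open speak of the compounds shown alone.

compound 1 `O=C1C=C(N2CCN(c3ccc(F)cc3)CC2)C(=O)c2ccccc21`: 11700 nM
compound 2 `O=C1C=C(N2CCN(c3ccccc3)CC2)C(=O)c2ccccc21`: 9900 nM
compound 3 `Cc1cccc(N2CCN(C3=CC(=O)c4ccccc4C3=O)CC2)c1`: 7400 nM

These three compounds were tested in a functional assay on DU-145 cells (Homo sapiens) for inhibition, read by MTT assay, with a stated time of 72 h; on this read-out lower numbers stand for stronger inhibition and higher numbers for weaker inhibition. There, compound 3 gives 7400 nM, a value that cannot be separated from the other two: the data show a 1.3-fold lower number from compound 2 to compound 3 (0.13 log units; within the scatter) and a 1.6-fold lower number from compound 1 to compound 3 (0.20 log units; within the scatter). The next compound, compound 4 `COc1ccccc1N1CCN(C2=CC(=O)c3ccccc3C2=O)CC1`, has not yet been measured. It carries a new group on the same core: 2-methoxyphenyl in place of 3-methylphenyl on an amine nitrogen in a ring.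

Among the compounds with values here, no measured compound has a 2-methoxyphenyl group, so no step shows this change directly. The nearest evidence comes from the other changes to the group at this place on the amine nitrogen. These are a 1.2-fold lower number from compound 1 to compound 2 (0.07 log units; within the scatter), a 1.3-fold lower number from compound 2 to compound 3 (0.13 log units; within the scatter) and a 1.6-fold lower number from compound 1 to compound 3 (0.20 log units; within the scatter). All three are small, and none stands out from the scatter. On that evidence, no step beyond the scatter is expected in this assay, and no direction can be favoured. However, the three measured compounds say little about a group that brings in a hydrogen-bond acceptor, so the range is kept wide. The expected change is a 1.1-fold higher number from compound 3 to compound 4 (0.03 log units; within the scatter). For compound 4 the estimated value is 8000 nM, with an expected range from 3500 nM to 17000 nM.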

Compound 4, half-maximal inhibitory concentration: 8000 nM
Compound 4: middle estimate and measured number agree at the digits printed, and the stated range covers the measured number.
By their numbers in this assay, from the lowest: compounds 3, 4, 2 and 1 (each within the scatter of the next).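

In this assay, the 2-methoxyphenyl group brings a hydrogen-bond acceptor to this place on the amine nitrogen, whereas the 3-methylphenyl group it replaces has none, and the number does not move outside the scatter (a 1.1-fold higher number from compound 3 to compound 4 (0.03 log units; within the scatter)). The same holds when compound 4 is set against the two other compounds (a 1.2-fold lower number from compound 2 to compound 4 (0.09 log units; within the scatter); a 1.5-fold lower number from compound 1 to compound 4 (0.17 log units; within the scatter)), so all six steps among the four compounds now lie within the scatter, and this read-out cannot tell the four groups on the amine nitrogen apart, with or without that acceptor. Nothing in the data at hand accounts for this flat result.

What the compounds shown leave open is whether a group of a different kind at this place, such as a benzyl, a pyridine ring, or a phenyl ring carrying a carboxylic acid or an amine, would give a step beyond the scatter. They also leave open whether changes to the shared core itself, rather than to the group on the amine nitrogen, would move the number in this assay.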